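The source may report more compounds than this note shows. Statements on the series, on what has been measured and on what is new or still open speak of the compounds shown alone.

Series notes. Compound 1 `COc1cc(N/C=C\C(=O)c2cn(-c3ccccc3)nc2-c2ccc(F)cc2)cc(OC)c1OC` gives 12600 nM in a functional assay on U-87MG ATCC cells (Homo sapiens) for antiproliferative activity, read by MTT assay, with a stated time of 48 h; a higher number here means a weaker inhibitor, a lower number a stronger inhibitor. Compound 2 `COc1ccc(N/C=C\C(=O)c2cn(-c3ccccc3)nc2-c2ccc(Cl)cc2)cc1` gives 6890 nM in this assay, a gap to compound 1 that lies within the scatter, so the two stand level. Compound 3 `COc1ccc(N/C=C\C(=O)c2cn(-c3ccccc3)nc2-c2ccc(OC)cc2)cc1` returns only a limit, > 50000 nM, in this assay. Compound 1 thus carries the higher of the two real numbers, with compound 2 close by, while the third value is a limit. Among the measured compounds shown here, the single step measured in one place, an at least 7.2-fold higher number from compound 2 to compound 3 (0.86 log units; beyond the scatter), shows methoxy in place of chloro weakening inhibition to an at least modest degree. That weakening ran into (the limit of > 50000 nM in this assay, at which 1 of the 3 values shown sits).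

Compound 4 `COc1cc(N/C=C\C(=O)c2cn(-c3ccccc3)nc2-c2cc(OC)c(OC)c(OC)c2)cc(OC)c1OC` differs from compound 1 by 3,4,5-trimethoxyphenyl in place of 4-fluorophenyl on an aromatic carbon. This again brings methoxy groups onto the aryl ring on the shared core, so the measured step is the nearest guide, and a weakening of similar or larger size is expected in this assay. Compound 4 is therefore expected to give about 40000 nM (range 12000 nM to 150000 nM). The expected step is a 3.2-fold higher number from compound 1 to compound 4 (0.50 log units; beyond the scatter), with a fair chance that only a limit is returned.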

Compound 4, half-maximal inhibitory concentration: 5100 nM
For compound 4 the middle estimate is 7.8-fold (0.89 log units) above the measured one; the measured number lies below the stated range.
By their numbers in this assay, from the lowest: compounds 4, 2 and 1 (each within the scatter of the next, the first and the last beyond it). At a limit, above all of these: compound 3.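

In this assay the change gives a 2.5-fold lower number from compound 1 to compound 4 (0.39 log units; beyond the scatter), so this position on the shared core accepts 3,4,5-trimethoxyphenyl in place of 4-fluorophenyl with a modest gain rather than a loss. Methoxy on this aryl ring therefore does not weaken inhibition in every case: the earlier step, an at least 7.2-fold higher number from compound 2 to compound 3 (0.86 log units; beyond the scatter), runs the other way, but it starts from a compound that differs elsewhere on the shared core, so the two steps cannot be read as one effect. Nothing measured here accounts for the gain.

On these data alone, it remains open whether all three methoxy groups are needed for this gain or whether a single one would give it on the core of compound 1. Also open, as far as these compounds go, is how an amine or a carboxylic acid on this aryl ring would read in this assay.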